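The compounds below may be only part of what the source reports. "The series", "measured", "known", "first", "only" and "open" are said of these compounds alone.

Working notes on three amides sharing one core, read in a functional assay on MCF7 cells (Homo sapiens) for inhibition, read by MTT assay; on this read-out lower numbers stand for stronger inhibition of growth and higher numbers for weaker inhibition of growth. Compound 1 (`COc1cc2oc(-c3cccc(NC(=O)c4ccccc4)c3)cc(=O)c2c(OC)c1OC`) gives 12100 nM, compound 2 (`COc1cc2oc(-c3cccc(NC(=O)c4cccc(Br)c4)c3)cc(=O)c2c(OC)c1OC`) gives 6340 nM, and compound 3 (`COc1cc2oc(-c3cccc(NC(=O)c4ccc(F)cc4)c3)cc(=O)c2c(OC)c1OC`) gives 14700 nM. Compound 2 is level with one neighbour and apart from the other, the steps being a 1.9-fold lower number from compound 1 to compound 2 (0.28 log units; within the scatter) and a 2.3-fold higher number from compound 2 to compound 3 (0.37 log units; beyond the scatter). The remaining step is a 1.2-fold higher number from compound 1 to compound 3 (0.08 log units; within the scatter).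

Compound 4 (`COc1cc2oc(-c3cccc(NC(=O)c4cccc(Br)c4)c3)cc(=O)c2c(O)c1OC`) departs from compound 2 by hydrogen in place of methyl on an oxygen on an aromatic ring, with hydrogen in place of methyl on an oxygen on an aromatic ring, that is, methoxy to hydroxy. Among the measured compounds shown here, no measured step covers this change, since all three alter the group on the carbonyl carbon. They bear on it only indirectly, as a guide to how far numbers have moved in this small set, and the largest, a 2.3-fold higher number from compound 2 to compound 3 (0.37 log units; beyond the scatter), is modest. The data offer no direction, so no step beyond the scatter is expected in this assay, though with wide uncertainty. The expected step is a 1.1-fold lower number from compound 2 to compound 4 (0.02 log units; within the scatter). The estimate for compound 4 is 6000 nM, with an expected range of 2000 nM to 18000 nM.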

Compound 4, concentration for 50% growth inhibition: 6940 nM
Beside the measured number, compound 4's estimate is 1.2-fold (0.06 log units) below it; the range from low to high includes it.
By their numbers in this assay, from the lowest: compounds 2, 4, 1 and 3 (each within the scatter of the next, the first and the last beyond it).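

In this assay, among the compounds shown here, the change of methoxy to hydroxy reads a 1.1-fold higher number from compound 2 to compound 4 (0.04 log units; within the scatter) and is the first step in this set that leaves the group on the carbonyl carbon untouched. On the amide of compound 2, the methyl on this oxygen on an aromatic ring can therefore give way to hydrogen without a step beyond the scatter, though this rests on a single pair. No evidence at hand bears on why the number holds level.

Going by these compounds, whether the same change holds on the amides of compound 1 and compound 3 remains open, as does the effect of the same change at the remaining methoxy groups. Also open, on these data alone, is how an ethyl group or longer chain on this oxygen, or an amine in place of the hydroxy, would read in this assay on this core.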